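Halogenated cytosine nucleosides against P815 cell growth

A few compounds are considered here, and "the series" means these few. Any claim that something is new, unique, unknown or untested is made for them only; others in the source may bear on it.

Compound 1 `Nc1nc(=O)n(C2OC(CO)C(I)C2O)cc1F` serves as the reference; in a functional assay on P815 cells (Mus musculus) for antiproliferative activity (a higher number here means a weaker inhibitor, a lower number a stronger inhibitor), compound 1 gives 8 ug/mL. Compound 2 `Nc1nc(=O)n(C2OC(CO)C(Cl)C2O)cc1F` carries chloro in place of iodo on a saturated ring carbon. In this assay compound 2 returns only a limit, > 30 ug/mL. The resulting step, an at least 3.7-fold higher number from compound 1 to compound 2 (0.57 log units; beyond the scatter), is bounded by the limit of > 30 ug/mL in this assay, at which 1 of the 3 values shown sits. Compound 3 `Nc1ccn(C2OC(CO)C(I)C2O)c(=O)n1` differs from compound 1 by hydrogen in place of fluoro on an aromatic carbon. In this assay compound 3 likewise returns only a limit, > 100 ug/mL. The step of an at least 12-fold higher number from compound 1 to compound 3 (1.09 log units; beyond the scatter) rests on (the limit of > 100 ug/mL in this assay, at which 1 of the 3 values shown sits). Compound 4 `Nc1ccn(C2OC(CO)C(Cl)C2O)c(=O)n1` is not yet measured; it differs from compound 3 by chloro in place of iodo on a saturated ring carbon, the same kind of change as that between compound 1 and compound 2, though here the place is two ring bonds from the ring atom that bears a group of 8 heavy atoms rather than 9. The expected step is a step that the limit leaves unreadable from compound 3 to compound 4, set beside the measured at least 3.7-fold higher number from compound 1 to compound 2 (0.57 log units; beyond the scatter). This expectation rests on compound 3 already standing at a limit, > 100 ug/mL. The estimate for compound 4 in this assay is 400 ug/mL, most likely reported as a limit only.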

Compound 4, concentration for 50% inhibition: > 100 ug/mL
Compound 4 ended at the assay's limit; the forecaster's own chance of this, stated with the estimate: 90%; the middle value lies beyond the limit too.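

In this assay, going by these compounds alone, compound 4 gives > 100 ug/mL, a limit, so no step from compound 3 or compound 2 to compound 4 can be read. The compounds shown leave open whether chloro in place of iodo matters without the fluoro.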